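A few compounds are considered here, and "the series" means these few. Any claim that something is new, unique, unknown or untested is made for them only; others in the source may bear on it.

Measured so far in a functional assay on MDA-MB-231 cells (Homo sapiens) for inhibition, read by sulforhodamine B assay, with a stated time of 48 h, tested at 0.01 uM; a higher number here means a weaker effect of the compound at the concentration tested, a lower number a stronger effect:
- compound 1, `O=C(Nc1cccc(-n2cc(-c3ccncc3)c(-c3cc(O)cc(Cl)c3)n2)c1)Nc1ccc(Cl)c(C(F)(F)F)c1`, gives 105%
- compound 2, `O=C(Nc1cccc(-n2cc(-c3ccncc3)c(-c3cc(O)cc(Cl)c3)n2)c1)Nc1ccc(Cl)c(Cl)c1`, gives 94%
- compound 3, `COc1cc(Cl)cc(-c2nn(-c3cccc(NC(=O)Nc4cc(C(F)(F)F)cc(C(F)(F)F)c4)c3)cc2-c2ccncc2)c1`, gives 97%

All three numbers sit close to no effect at the concentration tested. Compound 2 has the lowest of the three values; its gap to compound 3 is within the scatter, while its gap to compound 1 is beyond it. Among the measured compounds shown here, the one single-point step in the set is a number 11 percentage points lower from compound 1 to compound 2 (beyond the scatter), a modest move that comes with chloro in place of trifluoromethyl on an aromatic carbon.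

The next compound, compound 4, `COc1cc(Cl)cc(-c2nn(-c3cccc(NC(=O)Nc4ccc(Cl)c(Cl)c4)c3)cc2-c2ccncc2)c1`, differs from compound 2 in one place: methyl in place of hydrogen on an oxygen on an aromatic ring. For the measured compounds named here, no measured pair shows this change on its own. Compounds 2 and 3 do differ at the same oxygen, but they also differ in the groups on the other urea aryl ring, so their values, which lie within the scatter of each other, carry no clean signal for the hydroxy to methoxy change. With nothing bearing directly on the step, the expectation in this assay is a step of about a number 2 percentage points higher from compound 2 to compound 4 (within the scatter), that is none beyond the scatter. Compound 4 is therefore estimated at 96%, with a range from 84% to 108%.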

Compound 4, a percentage reported as activity, at one concentration (the size of the read-out at that concentration, not a potency): 109%
Beside the measured number, compound 4's estimate is 13 percentage points below it, and the stated range ends below it.
By their numbers in this assay, from the lowest: compounds 2, 3, 1 and 4 (each within the scatter of the next, the first and the last beyond it).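

In this assay, among the compounds shown here, the change from hydroxy to methoxy on the 3-chloro-5-hydroxyphenyl ring, with the rest of compound 2 held fixed, gives a number 15 percentage points higher from compound 2 to compound 4 (beyond the scatter) and provides the first clean reading at this oxygen. The pair of compound 2 and compound 3 could not give this reading. Their urea aryl rings also differ. Replacing the hydrogen on this oxygen with methyl is therefore not neutral in this read-out, although the step is modest and compound 4, at 109%, joins the others close to no effect at the single concentration tested, so it says nothing about potency. Nothing available accounts for the direction or size of the step.

The compounds shown leave open whether the same step appears with other urea aryl rings, since it rests on one matched pair, and how a longer chain on this oxygen, such as ethoxy, or an amine in place of the hydroxy would read. Also open is whether any of these compounds gives a clearly lower number at a higher concentration, where differences at this position could be read further from no effect.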